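Piperidine substituent exchange in the stilbene ether series

The source may hold more compounds than are shown below. What is called first, only, known or untested is meant among the compounds shown, and "the series" means these compounds.

Compound 3 `OCC1CCCN(CCCCOc2ccccc2/C=C/c2ccccc2)C1` gives 12.5% in a functional assay on the whole organism with Mus musculus as the target, in the maximal electroshock model, at a dose of 50 mg/kg by the oral route (a higher number here means more inhibition at the dose given (going by the name of the read-out), a lower number less inhibition), the lowest of the three numbers in hand. Compound 1 `C(=C/c1ccccc1OCCCCN1CCCCC1)\c1ccccc1` gives 42.9% and compound 2 `CCCN1CCN(CCCCOc2ccccc2/C=C/c2ccccc2)CC1` gives 42.9%. The step of no change at the digits printed from compound 1 to compound 2 (within the scatter) stays within the scatter, whereas a number 30.4 percentage points lower from compound 1 to compound 3 (beyond the scatter) and a number 30.4 percentage points lower from compound 2 to compound 3 (beyond the scatter) are both large drops. Compound 4 `NC(=O)C1CCCN(CCCCOc2ccccc2/C=C/c2ccccc2)C1` differs from compound 3 by carbamoyl in place of hydroxymethyl on a saturated ring carbon. Within the data shown here, no measured step bears directly on this exchange: the two steps onto compound 3 only show the effect of hydroxymethyl against hydrogen or against 4-propylpiperazin-1-yl. The counted difference is small, one donor and one acceptor on either side. A change from compound 3 to compound 4 of a number 5.5 percentage points higher from compound 3 to compound 4 (within the scatter) is expected, within the scatter. Compound 4 is estimated at 18%, ranging from 0% to 45%.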

Compound 4, a percentage reported as inhibition, in the whole organism at one dose (the size of the read-out at that dose, not a potency): 0%
Estimate against measurement, compound 4: 18 percentage points above; the measured number falls inside the stated range.
By their numbers in this assay, from the lowest: compound 4; then compound 3; then compounds 1 and 2 (each within the scatter of the next).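

In this assay, the exchange on this saturated ring carbon, two ring bonds from the ring nitrogen, is not neutral: a number 12.5 percentage points lower from compound 3 to compound 4 (beyond the scatter), although the counted donors and acceptors stay the same. Carbamoyl in place of hydrogen gives a number 42.9 percentage points lower from compound 1 to compound 4 (beyond the scatter), and 3-carbamoylpiperidin-1-yl in place of 4-propylpiperazin-1-yl gives a number 42.9 percentage points lower from compound 2 to compound 4 (beyond the scatter), which makes compound 4 the lowest of the four. Nothing at hand accounts for these drops.

On these data alone, whether aminomethyl or a carboxylic acid on this ring carbon would read closer to hydroxymethyl or to carbamoyl stays open. So does the effect of carbamoyl on a different ring carbon.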